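This account rests on a few compounds, and the source may have more. Where it says the series, first, only, none or still open, it means among the compounds named here.

Compounds and values in an assay on isolated protein for inhibition of Amine oxidase [flavin-containing] A (Homo sapiens), read by fluorescence and Amplex Red, with a stated time of 30 min, tested at 1 nM; a higher number here means a stronger effect of the compound at the concentration tested, a lower number a weaker effect:
compound 1 `CCCCNc1nnc(SCC(=O)N(Cc2cccc([N+](=O)[O-])c2)c2ccc(F)cc2)s1`: 19.7%
compound 2 `CC(C)CNc1nnc(SCC(=O)N(Cc2cccc([N+](=O)[O-])c2)c2ccc(F)cc2)s1`: 17.3%
compound 3 `COCCNc1nnc(SCC(=O)N(Cc2cccc([N+](=O)[O-])c2)c2ccc(F)cc2)s1`: 26.9%

All three sit close together; compound 3 carries the highest number, but its steps to the others, a number 7.2 percentage points higher from compound 1 to compound 3 (within the scatter) and a number 9.6 percentage points higher from compound 2 to compound 3 (within the scatter), both stay within the scatter, so no ordering among the three can be read.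

Compound 4 `C=CCNc1nnc(SCC(=O)N(Cc2cccc([N+](=O)[O-])c2)c2ccc(F)cc2)s1` is the next member. It differs from compound 3 as follows: vinyl in place of methoxymethyl on a saturated chain carbon bound to a nitrogen on an aromatic ring. Among the measured compounds shown here, the steps that bear on this are the chain variations already seen, a number 2.4 percentage points lower from compound 1 to compound 2 (within the scatter) and a number 7.2 percentage points higher from compound 1 to compound 3 (within the scatter), all within the scatter. For the measured compounds named here, no step therefore gives ground to expect a change beyond the scatter in this assay; the expected step of a number 5.9 percentage points lower from compound 3 to compound 4 (within the scatter) is small and near zero.

Compound 4 is estimated at 21%, with a range from 10% to 32%.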

Compound 4, a percentage reported as inhibition, at one concentration (the size of the read-out at that concentration, not a potency): 20.5%
Compound 4: the middle estimate sits 0.5 percentage points above what was measured, and the stated range covers the measured number.
By their numbers in this assay, from the lowest: compounds 2, 1, 4 and 3 (each within the scatter of the next).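

Among the compounds shown here, at the saturated chain carbon bound to a nitrogen on an aromatic ring, vinyl now stands with the saturated and ether-bearing chains, and in this assay no step to it leaves the scatter (a number 6.4 percentage points lower from compound 3 to compound 4 (within the scatter)) and (a number 3.2 percentage points higher from compound 2 to compound 4 (within the scatter)) and (a number 0.8 percentage points higher from compound 1 to compound 4 (within the scatter)). A double bond outside aromatic rings therefore adds no readable change here, and neither does removing the oxygen of methoxymethyl. No measurement at hand gives a reason for these numbers.

From the compounds shown here alone, whether a longer chain, an amine or a carboxylic acid at this position would give a step beyond the scatter stays open. So does whether a phenyl ring there would do so.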